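The source may report more compounds than this note shows. Statements on the series, on what has been measured and on what is new or still open speak of the compounds shown alone.

In a functional assay on the whole organism with Canis familiaris (Canis lupus familiaris) as the target (on this read-out higher numbers stand for an effect only at larger amounts of compound and lower numbers for an effect already at smaller amounts), compound 1 `OC(CSc1[nH]cnc2ncnc1-2)CN1CCN(C(c2ccccc2)c2ccccc2)CC1` gives 0.63 mg/kg, and compound 2 `Nc1nc(SCC(O)CN2CCN(C(c3ccc(F)cc3)c3ccc(F)cc3)CC2)c2[nH]cnc2n1` gives 0.85 mg/kg. These two numbers lie within the usual scatter of each other, so compound 2 cannot be told apart from compound 1. Compound 3 `OC(CNc1[nH]cnc2ncnc1-2)CN1CCN(C(c2ccc(F)cc2)c2ccc(F)cc2)CC1` differs from compound 2 by a single exchange: a group of 10 heavy atoms (5 carbon, 5 nitrogen; one five-membered aromatic ring with 2 hetero atoms, one six-membered aromatic ring with 2 hetero atoms) in place of a group of 11 heavy atoms (5 carbon, 5 nitrogen, 1 sulfur; one five-membered aromatic ring with 2 hetero atoms, one six-membered aromatic ring with 2 hetero atoms), on a saturated chain carbon, two bonds along the chain from an oxygen on a saturated carbon. Going by the values given here, no measured pair shows this change, so only a small step towards a higher number in this assay, not clearly beyond the scatter, is expected. The estimated step is a 1.8-fold higher number from compound 2 to compound 3 (0.25 log units; within the scatter). For compound 3 the expected value is 1.5 mg/kg, with an estimated range from 0.4 mg/kg to 6 mg/kg.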

Compound 3, dose for half-maximal effect: 0.28 mg/kg
Compound 3: middle estimate off by 5.4-fold (0.73 log units), on the high side; measured number outside the range, below it.
By their numbers in this assay, from the lowest: compound 3; then compounds 1 and 2 (each within the scatter of the next).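

In this assay, going by these compounds alone, the exchange on this saturated chain carbon, two bonds along the chain from an oxygen on a saturated carbon, gives the first step beyond the scatter: a 3.0-fold lower number from compound 2 to compound 3 (0.48 log units; beyond the scatter). The place therefore responds when the group of 10 heavy atoms replaces the group of 11 heavy atoms that holds the sulfur. No available measurement accounts for this step.

Since the whole group changes at once, the compounds shown do not separate the contributions of its parts. From the compounds shown here alone, how an ether oxygen in the same place would compare also remains open.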